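Swapping the Sulfur-Linked Ring on a Hydrazone Scaffold

The source may report more compounds than this note shows. Statements on the series, on what has been measured and on what is new or still open speak of the compounds shown alone.

Of the compounds shown here, two have been measured in a functional assay on Huh-7 cells (Homo sapiens) for inhibition, read by MTT assay, with a stated time of 72 h; on this read-out lower numbers stand for stronger inhibition and higher numbers for weaker inhibition. Compound 1, `O=C(CSc1nc2ccccc2s1)N/N=C/c1c[nH]c2ccccc12`, gives 32.9 ug/mL in this assay. Compound 2, `COc1cc(/C=N/NC(=O)c2ccc(CSc3nc4ccccc4s3)cc2)cc(OC)c1OC`, is known only by a limit: in this assay compound 2 gives > 80 ug/mL, which is the limit of the assay rather than a number, the situation described by the limit of > 80 ug/mL in this assay, at which 1 of the 2 values shown sits. Among the compounds with values here, compound 1 and compound 2 differ in more than one place, so their two values show only that compound 1 inhibits at a measurable concentration while compound 2 does not.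

Compound 3, `COc1cc(/C=N/NC(=O)c2ccc(CSc3nc(C)cc(C)n3)cc2)cc(OC)c1OC`, is yet to be measured. It differs from compound 2 by 4,6-dimethylpyrimidin-2-yl in place of 1,3-benzothiazol-2-yl on a sulfur. Within the data shown here, no step between measured compounds is available, so nothing within this study shows how such a change behaves. Since compound 2 already sits at the limit, the expectation in this assay is a step of no size beyond the scatter, with compound 3 most likely again returning a limit rather than a number; the expected step is a step that the limit leaves unreadable from compound 2 to compound 3. Compound 3 is estimated at 90 ug/mL, within a range from 40 ug/mL to 250 ug/mL.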

Compound 3, half-maximal inhibitory concentration: 17.4 ug/mL
Beside the measured number, compound 3's estimate is 5.2-fold (0.71 log units) above it, and the stated range ends above it.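

In this assay, within the data shown here, placing 4,6-dimethylpyrimidin-2-yl instead of 1,3-benzothiazol-2-yl on the sulfur gives an at least 4.5-fold lower number from compound 2 to compound 3 (0.66 log units; beyond the scatter), which is the only comparison here that changes a single place. On these data alone, compound 2 is known only by a limit of the assay and not by a number, so this step gives a minimum size and its full size stays unknown: the limit of > 80 ug/mL in this assay, at which 1 of the 3 values shown sits. Even so, the result shows that the group on this sulfur can move the read-out, and that the core shared by compound 2 and compound 3 does not by itself keep a compound at the limit.

The change alters several things at once, including the ring system, the ring atoms and the methyl groups, so these compounds cannot show which of these features matters. An unsubstituted pyrimidin-2-yl or a pyridin-2-yl on the same sulfur would help separate them, while 4,6-dimethylpyrimidin-2-yl on the core of compound 1 would test whether the gain carries over to a different core.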